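The compounds below may be only part of what the source reports. "The series", "measured", "known", "first", "only" and "open" are said of these compounds alone.

Working notes on the series in a functional assay on MGC-803 cells (Homo sapiens) for antiproliferative activity, read by CellTiter-Glo, with a stated time of 72 h; a higher number here means a weaker inhibitor, a lower number a stronger inhibitor. Compound 3 `O=C(NO)c1ccc(/C=C/c2ccnc(Br)c2)cc1` reads > 10000 nM, which is a limit of the assay and not a number. Two analogues with a ring at the same place give numbers: compound 1 `COc1ccccc1-c1cc(/C=C/c2ccc(C(=O)NO)cc2)ccn1` gives 6350 nM, and compound 2 `Cc1ccc(-c2cc(/C=C/c3ccc(C(=O)NO)cc3)ccn2)cc1` gives 1910 nM. The 4-methylphenyl and 2-methoxyphenyl groups are not interchangeable, as a 3.3-fold lower number from compound 1 to compound 2 (0.52 log units; beyond the scatter) shows.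

Compound 4 `O=C(NO)c1ccc(/C=C/c2ccnc(-c3ccsc3)c2)cc1` carries thiophen-3-yl in place of bromo on an aromatic carbon. The nearest evidence is the same kind of exchange run the other way. There is an at least 5.2-fold higher number from compound 2 to compound 3 (0.71 log units; beyond the scatter), beyond the scatter, and an at least 1.5-fold higher number from compound 1 to compound 3 (0.19 log units; that floor lies within the scatter), whose floor lies within it. Both are bounded on one side only, so the size of the coming step in this assay is uncertain, but a drop to a lower number is expected, of modest size or more. The expected move is an at least 3.3-fold lower number from compound 3 to compound 4 (0.52 log units; beyond the scatter). The estimate for compound 4 is 3000 nM, with an expected range of 1000 nM to 9000 nM.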

Compound 4, half-maximal inhibitory concentration: 3680 nM
For compound 4 the middle estimate is 1.2-fold (0.09 log units) below the measured one; the measured number falls inside the stated range.
By their numbers in this assay, from the lowest: compounds 2, 4 and 1 (each within the scatter of the next, the first and the last beyond it). At a limit, above all of these: compound 3.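

In this assay, thiophen-3-yl on the aromatic carbon next to the ring nitrogen gives a measurable number where bromo does not, with an at least 2.7-fold lower number from compound 3 to compound 4 (0.43 log units; beyond the scatter). Compound 3 is a limit and not a number, and this step therefore has only a floor: the limit of > 10000 nM in this assay, at which 1 of the 4 values shown sits. The five-membered ring cannot be told apart from either six-membered aryl group, with a 1.9-fold higher number from compound 2 to compound 4 (0.28 log units; within the scatter) and a 1.7-fold lower number from compound 1 to compound 4 (0.24 log units; within the scatter), both within the scatter, and all three ring-bearing compounds give numbers.

The compounds shown leave open whether a ring is needed at this place at all, or whether an amine or a longer alkyl chain in place of bromo would also bring a measurable number. They also leave open whether a carboxylic acid on the attached ring would keep that number.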